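The source may hold more compounds than are shown below. What is called first, only, known or untested is meant among the compounds shown, and "the series" means these compounds.

Three measured compounds share one core and differ in the group attached to the double-bonded chain. For the measured compounds named here, compound 1 `COc1ccc(/C=C/C(=O)c2ccc(OC)c3c2OC(C)(C)C=C3)c(F)c1` carries a 2-fluoro-4-methoxyphenyl group there; in a functional assay on SW-620 cells (Homo sapiens) for antiproliferative activity, read by MTT assay, with a stated time of 24 h (a higher number here means a weaker inhibitor, a lower number a stronger inhibitor), compound 1 gives 6570 nM, which is the higher of the two numbers known. Compound 2 `COc1ccc(C(=O)/C=C/c2ccc3ccccc3n2)c2c1C=CC(C)(C)O2` carries a different aromatic group and in this assay gives 2250 nM, a lower number than that of compound 1 by a margin beyond the usual scatter. Compound 3 `COc1ccc(C(=O)/C=C/c2ccc(OC)c(OC)c2OC)c2c1C=CC(C)(C)O2` has yet another substituent; in this assay compound 3 reaches only a limit, > 10000 nM, so no number is known for it (the limit of > 10000 nM in this assay, at which 1 of the 3 values shown sits).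

Compound 4 `COc1ccc(C(=O)/C=C/c2ccccn2)c2c1C=CC(C)(C)O2` has not been measured. It differs from compound 1 in one place: pyridin-2-yl in place of 2-fluoro-4-methoxyphenyl on a double-bonded chain carbon bound to a double-bonded chain carbon. Going by the values given here, no measured pair shows this exact change, so the expectation rests on compound 2, whose nitrogen-holding aromatic group gives 2250 nM. The step from compound 1 to compound 4 is expected to be modest, toward a stronger inhibitor, as a 1.6-fold lower number from compound 1 to compound 4 (0.22 log units; within the scatter). Compound 4 is therefore estimated at 4000 nM, with a likely range from 1500 nM to 12000 nM.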

Compound 4, half-maximal inhibitory concentration: 5000 nM
Beside the measured number, compound 4's estimate is 1.3-fold (0.10 log units) below it, within the range that was stated.
By their numbers in this assay, from the lowest: compound 2; then compounds 4 and 1 (each within the scatter of the next). At a limit, above all of these: compound 3.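

For the compounds shown here, this is the first comparison at this chain carbon in which only one group differs: in this assay there is a 1.3-fold lower number from compound 1 to compound 4 (0.12 log units; within the scatter). Compounds 1 and 4 therefore cannot be told apart here, even though pyridin-2-yl replaces 2-fluoro-4-methoxyphenyl and so brings a ring nitrogen while the fluorine and the methoxy group leave. Nothing on hand explains this result, as the only supporting note concerns a limit reached by another compound.

The compounds shown leave open what happens if the aromatic ring at this place gives way to a non-aromatic group, such as an amine, a carboxylic acid or a longer alkyl chain. They also leave open whether pyridin-3-yl or pyridin-4-yl, with the ring nitrogen placed elsewhere, would read the same as pyridin-2-yl.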